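Ring exchange on the thiocarbonyl carbon of compound 1

The compounds below may be only part of what the source reports. "The series", "measured", "known", "first", "only" and "open" are said of these compounds alone.

Compound 1 `Cc1ccnc(/C(N)=N/NC(=S)N2CCSCC2)c1` was tested in a functional assay on MCF7 cells (Homo sapiens) for cytotoxicity, read by MTT assay, with a stated time of 72 h, tested at 10 uM (on this read-out lower numbers stand for less inhibition of growth and higher numbers for more inhibition of growth at the one concentration tested), where compound 1 gives 62.5%. For the measured compounds named here, its only measured neighbour is compound 2 `N/C(=N\NC(=S)N1CCSCC1)c1ccccn1`, which differs by hydrogen in place of methyl on an aromatic carbon; in this assay compound 2 gives 54.3%, a step of a number 8.2 percentage points lower from compound 1 to compound 2 (within the scatter). Thus compound 1 shows the larger of the two numbers, but the two lie within the scatter of each other.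

Compound 3 `Cc1ccnc(/C(N)=N/NC(=S)N2CCCCC2)c1` has not yet been measured. It differs from compound 1 by piperidin-1-yl in place of thiomorpholin-4-yl on a thiocarbonyl carbon. Going by the values given here, no measured step touches this part of the molecule; the one step on record concerns the methyl on the aromatic ring and was itself within the scatter. With no evidence pointing either way, the expected change from compound 1 to compound 3 in this assay is a number 4.5 percentage points lower from compound 1 to compound 3 (within the scatter), nothing beyond the scatter. Compound 3 is therefore estimated at 58%, in the range 40% to 76%.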

Compound 3, percent growth inhibition at one concentration: 40.7%
For compound 3 the middle estimate is 17.3 percentage points above the measured one; the range from low to high includes it.
By their numbers in this assay, from the lowest: compound 3; then compounds 2 and 1 (each within the scatter of the next).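

In this assay, the exchange on the thiocarbonyl carbon gives a number 21.8 percentage points lower from compound 1 to compound 3 (beyond the scatter), so this position responds to a change that leaves the ring size and the count of heavy atoms as they were, and differs only in that a ring sulfur gives way to carbon. For the compounds shown here, the only earlier step, on the aromatic carbon, was a number 8.2 percentage points lower from compound 1 to compound 2 (within the scatter), which means this is the first change to move the read-out beyond the scatter. Nothing available explains why the thiomorpholin-4-yl compound gives the higher number.

The compounds shown leave open whether sulfur itself is needed, or whether another ring such as morpholin-4-yl or piperazin-1-yl would serve as well. They also leave open how an open-chain dimethylamino group would behave on this carbon, and whether the step would recur on the core of compound 2.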